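Ether-linked side chains on the shared core: compound 4

The source may report more compounds than this note shows. Statements on the series, on what has been measured and on what is new or still open speak of the compounds shown alone.

Measured compounds:
compound 1 `COc1ccc2c(c1)[n+]([O-])nc(NCOC(C)c1ccccc1)[n+]2[O-]`: in a functional assay on PC-3 cells (Homo sapiens) for cytotoxicity, read by MTT assay, with a stated time of 72 h (on this read-out higher numbers stand for weaker inhibition and lower numbers for stronger inhibition), compound 1 gives only a limit, > 100000 nM.
compound 2 `COCNc1n[n+]([O-])c2ccccc2[n+]1[O-]`: in this assay compound 2 gives 4270 nM.
compound 3 `COc1ccc(COCNc2n[n+]([O-])c3ccccc3[n+]2[O-])cc1`: in this assay compound 3 gives 52800 nM.

Compound 2 holds the lowest of the two numbers shown. Its nearest neighbour is compound 3, reached by a 12-fold higher number from compound 2 to compound 3 (1.09 log units; beyond the scatter), where 4-methoxyphenyl takes the place of hydrogen on a saturated chain carbon bound to an oxygen on a saturated carbon. The value of compound 1 is a limit of the assay and not a number (the limit of > 100000 nM in this assay, at which 1 of the 3 values shown sits).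

Compound 4 `CCCOCNc1n[n+]([O-])c2ccccc2[n+]1[O-]` differs from compound 2 by ethyl in place of hydrogen on a saturated chain carbon bound to an oxygen on a saturated carbon. Going by the values given here, the only measured step touching this place is a 12-fold higher number from compound 2 to compound 3 (1.09 log units; beyond the scatter), with 4-methoxyphenyl rather than ethyl entering. Ethyl is a different group from 4-methoxyphenyl, so the direction is taken from that step but its full size is not: a rise beyond the scatter yet well short of it is expected, namely a 2.1-fold higher number from compound 2 to compound 4 (0.32 log units; beyond the scatter). Compound 4 is therefore estimated at 9000 nM, within a range of 3500 nM to 25000 nM.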

Compound 4, half-maximal inhibitory concentration: 7400 nM
Compound 4: the middle estimate sits 1.2-fold (0.09 log units) above what was measured; measured number inside the range.
By their numbers in this assay, from the lowest: compounds 2 and 4 (each within the scatter of the next); then compound 3. At a limit, above all of these: compound 1.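

In this assay, methoxymethyl to propoxymethyl on the shared core gives no change that can be read: a 1.7-fold higher number from compound 2 to compound 4 (0.24 log units; within the scatter). Going by these compounds alone, this position therefore accepts ethyl on a saturated chain carbon bound to an oxygen on a saturated carbon, whereas the earlier compounds showed only the rise with 4-methoxyphenyl: a 12-fold higher number from compound 2 to compound 3 (1.09 log units; beyond the scatter). The direct comparison, a 7.1-fold lower number from compound 3 to compound 4 (0.85 log units; beyond the scatter), shows that this rise does not follow from any group entering here, but goes with 4-methoxyphenyl and not with ethyl.

Going by these compounds, whether a longer chain such as hexyl, an unsubstituted phenyl, an amine or a carboxylic acid at this place would behave like ethyl or like 4-methoxyphenyl remains open. Nothing given here bears on the cause of either step.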